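Swapping the Pendant Aryl Group in Compound 1

The source may hold more compounds than are shown below. What is called first, only, known or untested is meant among the compounds shown, and "the series" means these compounds.

Compound 1 `O=C1N=C(N2N=C(c3ccccc3)CC2c2ccccc2O)S/C1=C1/C(=O)Nc2ccccc21` was tested in a functional assay on cells (Cancer cell lines, Homo sapiens) for cytotoxicity, read by sulforhodamine B assay, with a stated time of 48 h (a lower number here means a stronger inhibitor of growth, a higher number a weaker inhibitor of growth), where compound 1 gives 2130 nM. For the measured compounds named here, of the two numbers measured so far this is the highest, so compound 1 is the weaker growth inhibitor of the pair. Going by the values given here, its only measured neighbour is compound 2 `O=C1N=C(N2N=C(c3ccccc3)CC2c2ccccc2O)S/C1=C1/C(=O)Nc2ccc(Br)cc21`, which in this assay gives 240 nM; the single change there, a bromo in place of hydrogen on an aromatic carbon, brought an 8.9-fold lower number from compound 1 to compound 2 (0.95 log units; beyond the scatter).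

Compound 3 `COc1ccc(C2CC(c3ccccc3)=NN2C2=NC(=O)/C(=C3\C(=O)Nc4ccccc43)S2)cc1` has not yet been measured. It differs from compound 1 at another site: 4-methoxyphenyl in place of 2-hydroxyphenyl on a saturated ring carbon. Among the compounds with values here, the one measured step alters a different part of the shared core, so it offers no direct guide to this exchange. With nothing to lean on, the expectation for this assay is a step of no clear direction, most likely within the scatter or at most modest. Compound 3 is therefore expected to give 2000 nM, with a range of 600 nM to 7000 nM. That estimate corresponds to an expected 1.1-fold lower number from compound 1 to compound 3 (0.03 log units; within the scatter).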

Compound 3, concentration for 50% growth inhibition: 1620 nM
Compound 3: the middle estimate sits 1.2-fold (0.09 log units) above what was measured; the range from low to high includes it.
By their numbers in this assay, from the lowest: compound 2; then compounds 3 and 1 (each within the scatter of the next).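

At the saturated ring carbon of the shared core, exchanging 2-hydroxyphenyl for 4-methoxyphenyl gives, in this assay, a 1.3-fold lower number from compound 1 to compound 3 (0.12 log units; within the scatter) and so leaves the two compounds indistinguishable in this measurement. For the compounds shown here, this is the first information about this position: the group that leaves carries a hydrogen-bond donor and the group that enters carries none, yet that difference, together with the added heavy atom, produces no step beyond the scatter for this pair. Going by these compounds alone, the only step so far that does go beyond the scatter remains the bromo exchange at the other site, with an 8.9-fold lower number from compound 1 to compound 2 (0.95 log units; beyond the scatter) as its size, although a single pair cannot show how tolerant this position is in general, and no measurement at hand explains why the number holds here.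

This exchange alters both the substituent on the aryl ring and where it sits, so the two changes cannot be separated, and they might even offset each other. Going by these compounds, it also remains open how this position would respond to a plain phenyl group, to an aryl ring bearing an amine or a carboxylic acid, or to 4-methoxyphenyl combined with the bromo group on the shared core.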